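The source may hold more compounds than are shown below. What is called first, only, known or untested is meant among the compounds shown, and "the series" means these compounds.

Measured in a functional assay on P388 cells (Mus musculus) for cytotoxicity, read by MTT assay, with a stated time of 72 h; a higher number here means a weaker inhibitor, a lower number a stronger inhibitor:
Compound 1 `Cc1c(/N=C/c2ccc(N(C)C)cc2)c(=O)n(-c2ccccc2)n1C`: 468000000 nM
Compound 2 `Cc1c(/N=C/c2ccccc2Cl)c(=O)n(-c2ccccc2)n1C`: 324000000 nM
Compound 3 `COc1cccc(/C=N/c2c(C)n(C)n(-c3ccccc3)c2=O)c1O`: 851000000 nM

Compound 2 has the lowest of the three numbers in this assay. Its nearest neighbour is compound 1, whose value lies within the scatter of repeated measurements, so the two cannot be ranked against each other; compound 3 stands further off, beyond the scatter. The next compound, compound 4 `Cc1c(/N=C/c2ccc(Cl)cc2)c(=O)n(-c2ccccc2)n1C`, differs from compound 2 in one place: 4-chlorophenyl in place of 2-chlorophenyl on a carbon with a double bond to nitrogen. Among the compounds with values here, no measured pair shows the effect of this change, so the size of the step is open. Given that only the position of the chlorine on the ring moves, the expectation is a step of a 1.1-fold higher number from compound 2 to compound 4 (0.03 log units; within the scatter) of no size beyond the scatter. Compound 4 is therefore estimated at 350000000 nM, within a range from 130000000 nM to 950000000 nM.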

Compound 4, half-maximal inhibitory concentration: 646000000 nM
The estimate for compound 4 lay 1.8-fold (0.27 log units) below the measured number, within the range that was stated.
By their numbers in this assay, from the lowest: compounds 2, 1, 4 and 3 (each within the scatter of the next, the first and the last beyond it).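

In this assay the chlorine's position on the ring, on a carbon with a double bond to nitrogen, gives the first step read at this place, and 4-chlorophenyl and 2-chlorophenyl cannot be told apart (a 2.0-fold higher number from compound 2 to compound 4 (0.30 log units; within the scatter)). Chloro in place of dimethylamino on an aromatic carbon also stays within the scatter (a 1.4-fold higher number from compound 1 to compound 4 (0.14 log units; within the scatter)). Nothing available explains either result. From the compounds shown here alone, whether a carboxylic acid or an amine on the aromatic ring would give a step beyond the scatter remains open.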